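Working notes: five-membered heteroaryl replacement

The compounds below may be only part of what the source reports. "The series", "measured", "known", "first", "only" and "open" are said of these compounds alone.

Compound 1 `c1ccc(-c2cnccn2)c(OCC2=NCCN2)c1` carries a pyrazin-2-yl group on an aromatic carbon of the shared core, and in a functional assay for activation of Alpha-1B adrenergic receptor (Homo sapiens), read by calcium flux (on this read-out lower numbers stand for an effect already at smaller amounts and higher numbers for an effect only at larger amounts of compound), compound 1 gives 631 nM. Compound 2 `Cc1csc(-c2ccccc2OCC2=NCCN2)n1` carries a 4-methyl-1,3-thiazol-2-yl group at that carbon instead. In this assay compound 2 reaches only a limit of the assay, < 100000 nM, so only a range is known for compound 2. The step that the limit leaves unreadable from compound 1 to compound 2 is therefore of unreadable size, as the limit of < 100000 nM in this assay, at which 1 of the 2 values shown sits, records. Compound 3 `Cn1nccc1-c1ccccc1OCC1=NCCN1` is the next member and is not yet measured in this assay. Its change from compound 2 is 1-methyl-1H-pyrazol-5-yl in place of 4-methyl-1,3-thiazol-2-yl on an aromatic carbon. Going by the values given here, the only measured step at this carbon is the one from compound 1 to compound 2, and its size cannot be read; no measured step compares two five-membered rings at this position. The step from compound 2 to compound 3 is estimated as a step that the limit leaves unreadable from compound 2 to compound 3, a move toward smaller amounts but of very uncertain size. Compound 3 is expected to give about 15000 nM in this assay, within a range from 1000 nM to 100000 nM, with a real chance that only a limit is again reported.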

Compound 3, half-maximal effective concentration: < 100000 nM
Compound 3: only a limit was reported; the forecaster's own chance of this, stated with the estimate: 45%; the middle value does not contradict the limit.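

No new step can be read: the steps from compound 1 and compound 2 to compound 3 remain unreadable, because compound 3 also gives only a limit of the assay: the limit of < 100000 nM in this assay, at which 2 of the 3 values shown sit.

The compounds shown leave open how compound 2 and compound 3 actually stand against compound 1 and against each other in this assay.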